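Cell survival of aminoglycoside-type compounds bearing alkyl chains

The compounds below may be only part of what the source reports. "The series", "measured", "known", "first", "only" and "open" are said of these compounds alone.

Of the compounds shown here, three sharing one sugar-based core have been tested in an ADME assay on J774 cells (Mus musculus) for cytotoxicity, read by MTT assay, with a stated time of 24 h, tested at 10 uM; on this read-out higher numbers stand for a weaker effect at the one concentration tested and lower numbers for a stronger effect. Compound 1, `CCCCCCCCCCCO[C@@H]1[C@@H](O)[C@H](O[C@H]2O[C@H](CN)[C@@H](O)[C@H](O)[C@H]2N)[C@@H](N)C[C@H]1N`, carries an undecyl chain on one oxygen and free hydroxyls elsewhere; in this assay compound 1 gives 74.7%. Compound 2, `CCCCCCCCCCCO[C@@H]1[C@@H](O)[C@H](O[C@H]2O[C@H](CN)[C@@H](O)[C@H](OCCCCCCC)[C@H]2N)[C@@H](N)C[C@H]1N`, adds a heptyl chain on a second oxygen, and in this assay compound 2 gives 82.9%. Compound 3, `CCCCCCCO[C@@H]1[C@@H](N)[C@@H](O[C@H]2[C@H](O)[C@@H](OCCCCCCC)[C@H](N)C[C@@H]2N)O[C@H](CN)[C@H]1O`, keeps that heptyl chain but shortens the undecyl chain to heptyl; in this assay compound 3 gives 96.3%, the highest of the three, leaving the cells least affected.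

Two single changes connect the measured compounds. Removing the heptyl chain, (hydrogen in place of heptyl on an oxygen on a saturated carbon), gave a number 8.2 percentage points lower from compound 2 to compound 1 (within the scatter). Shortening the longer chain, (hydrogen in place of butyl on a saturated chain carbon, seven bonds along the chain from an oxygen on a saturated carbon), gave a number 13.4 percentage points higher from compound 2 to compound 3 (beyond the scatter).

Compound 4, `CCCCCCCO[C@@H]1[C@@H](N)[C@@H](O[C@H]2[C@H](O)[C@@H](O)[C@H](N)C[C@@H]2N)O[C@H](CN)[C@H]1O`, is not yet measured. It differs from compound 3 by hydrogen in place of heptyl on an oxygen on a saturated carbon, the same kind of change as from compound 2 to compound 1, made at the same place on a different core; the two cores differ by hydrogen in place of butyl on a saturated chain carbon, seven bonds along the chain from an oxygen on a saturated carbon. Since that earlier step was small and within the scatter, the step from compound 3 to compound 4 is expected to be similarly small, a number 6.3 percentage points lower from compound 3 to compound 4 (within the scatter), also because compound 3 already sits high at 96.3%. Compound 4 is therefore estimated at 90%, likely between 76% and 100%.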

Compound 4, a percentage reported as activity, at one concentration (the size of the read-out at that concentration, not a potency): 77.5%
For compound 4 the middle estimate is 12.5 percentage points above the measured one; the measured number falls inside the stated range.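

Replacing heptyl with hydrogen on the oxygen gives, in this assay, a number 18.8 percentage points lower from compound 3 to compound 4 (beyond the scatter), and setting this beside the same change on the other core shows no firm difference between the two cores: the same change on two cores in this assay, a number 8.2 percentage points lower (within the scatter) from compound 2 to compound 1 and a number 18.8 percentage points lower (beyond the scatter) from compound 3 to compound 4, 10.6 percentage points apart, within the scatter of two such steps. For the compounds shown here, the change therefore points the same way on both cores, and although only one of the two steps lies beyond the scatter, the gap between them is too small to say that one core responds more than the other; it does not show that the two steps are equal in size, and two pairs of compounds cannot establish a rule for other cores. A different single change, hydrogen in place of undecyl on an oxygen, gives a number 5.4 percentage points lower from compound 2 to compound 4 (within the scatter), so compound 2 and compound 4 cannot be told apart in this read-out.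

The compounds shown leave open how cell survival would respond if the oxygen carried something other than heptyl or hydrogen, such as a butyl chain, a benzyl group, or a chain bearing an amine. They also leave open how the cells would respond at other concentrations, since a single concentration gives the size of an effect and not a potency.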